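Working notes on compound 4 and its change from compound 3

A few compounds are considered here, and "the series" means these few. Any claim that something is new, unique, unknown or untested is made for them only; others in the source may bear on it.

Measured compounds:
Compound 1 `CN(C)/C=N/c1c(C=O)c(-c2ccccc2)nn1-c1ccccc1`; in a functional assay on NCI-H661 cells (Homo sapiens) for inhibition, read by MTT assay, with a stated time of 72 h (a higher number here means a weaker inhibitor of growth, a lower number a stronger inhibitor of growth), compound 1 gives 31400 nM.
Compound 2 `Cc1ccc(-c2nn(-c3ccccc3)c(/N=C/N(C)C)c2C=O)cc1`; in this assay compound 2 gives 11900 nM.
Compound 3 `CN/C=N/c1cc(-c2ccccc2)nn1-c1ccccc1`; in this assay compound 3 gives only a limit, > 50000 nM.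

Compound 3 thus stands at the limit of > 50000 nM in this assay, at which 1 of the 3 values shown sits, and no number is known for it. Compound 4 `CC/C(=N\c1cc(-c2ccccc2)nn1-c1ccccc1)NC` differs from compound 3 by a group of 6 heavy atoms (4 carbon, 2 nitrogen; no ring) in place of a group of 4 heavy atoms (2 carbon, 2 nitrogen; no ring), on an aromatic carbon. For the measured compounds named here, the single measured step, a 2.6-fold lower number from compound 1 to compound 2 (0.42 log units; beyond the scatter), concerns a methyl on an aromatic carbon in another part of the shared core and does not bear on this change. For compound 4 no step beyond the scatter in this assay is therefore expected. Compound 4 is estimated at 60000 nM, range 20000 nM to 200000 nM, most likely again reported only as a limit. The expected step that the limit leaves unreadable from compound 3 to compound 4 is estimated to stay within the scatter.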

Compound 4, concentration for 50% growth inhibition: > 50000 nM
Compound 4: no number, only a limit; the forecaster's own chance of this, stated with the estimate: 80%; the middle value lies beyond the limit too.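

Compound 3 and compound 4 both stand only as limits, so no step between them can be read: the limit of > 50000 nM in this assay, at which 2 of the 4 values shown sit.

The compounds shown leave open whether the group of 6 heavy atoms, in place of the group of 4 heavy atoms, changes growth inhibition at all.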